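Notes on the amide side chain of a shared core

The source may hold more compounds than are shown below. What is called first, only, known or untested is meant among the compounds shown, and "the series" means these compounds.

Compound 3 `Cn1ccnc1SCC(=O)Nc1ccc(-c2nc(-c3ccccc3)c(-c3ccccc3)n2C)cc1` carries, on the chain carbon bound to the carbonyl, a sulfur bearing a methylated imidazole. Going by the values given here, in a functional assay on HT-29 cells (Homo sapiens) for cytotoxicity, read by MTT assay, with a stated time of 24 h, tested at 16 ug/mL (a higher number here means a stronger effect of the compound at the concentration tested, a lower number a weaker effect), compound 3 gives 36.5%, the lowest of the three numbers so far. Compound 1 `Cn1nnnc1SCC(=O)Nc1ccc(-c2nc(-c3ccccc3)c(-c3ccccc3)n2C)cc1` gives 72.5% in this assay, and compound 2 `Cn1c(-c2ccc(NC(=O)CSC3=NCCS3)cc2)nc(-c2ccccc2)c1-c1ccccc1` gives 43.3%. The measured steps are a number 36 percentage points lower from compound 1 to compound 3 (beyond the scatter), a number 29.2 percentage points lower from compound 1 to compound 2 (beyond the scatter) and a number 6.8 percentage points lower from compound 2 to compound 3 (within the scatter); each of them exchanges only the ring held on the sulfur, so all three show that the group beyond the sulfur moves the read-out, but none removes the sulfur itself.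

Compound 4 `CN1CCN(CC(=O)Nc2ccc(-c3nc(-c4ccccc4)c(-c4ccccc4)n3C)cc2)CC1` differs from compound 3 as follows: 4-methylpiperazin-1-yl in place of (1-methyl-1H-imidazol-2-yl)sulfanyl on a saturated chain carbon bound to a carbonyl carbon. Among the compounds with values here, no measured step bears directly on a change of this kind, since every earlier exchange kept the sulfur in place. In this assay, the step is therefore expected to stay within the scatter, a number 3.5 percentage points higher from compound 3 to compound 4 (within the scatter), with the wider spread of the three measured values as the uncertainty. Compound 4 is estimated at 40%, in the range 20% to 65%.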

Compound 4, a percentage reported as activity, at one concentration (the size of the read-out at that concentration, not a potency): 33.7%
For compound 4 the middle estimate is 6.3 percentage points above the measured one, and the stated range covers the measured number.
By their numbers in this assay, from the lowest: compounds 4, 3 and 2 (each within the scatter of the next); then compound 1.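

Notes on the sulfur exchange

Going by these compounds alone, this exchange is the first to remove the sulfur. With 4-methylpiperazin-1-yl on the saturated chain carbon bound to a carbonyl carbon, this assay gives two steps within the scatter (a number 2.8 percentage points lower from compound 3 to compound 4 (within the scatter); a number 9.6 percentage points lower from compound 2 to compound 4 (within the scatter)), so a sulfur is not needed for a read-out at the level of compound 2 and compound 3. The large step against the tetrazole-bearing side chain (a number 38.8 percentage points lower from compound 1 to compound 4 (beyond the scatter)) leaves compound 1 alone at the top of these four, and the sulfur in compound 2 and compound 3 shows that a sulfur alone does not give that read-out; nothing available explains these numbers.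

Still open, as far as these compounds go, is whether 1-methyl-1H-tetrazol-5-yl held directly on the chain carbon, without the sulfur, would keep the read-out of compound 1. Also open, from the compounds shown here alone, is how a piperazin-1-yl without its methyl, or a morpholin-4-yl, would read on the same chain carbon.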